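The source may report more compounds than this note shows. Statements on the series, on what has been measured and on what is new or still open speak of the compounds shown alone.

Compound 1, `COc1ccc(Oc2ccccc2-c2ccsc2S(=O)(=O)N2CCN(C(=S)Nc3ccc([N+](=O)[O-])cc3)CC2)cc1OC`, in a functional assay on RS4-11 cells (Homo sapiens) for inhibition, read by CCK-8 assay, with a stated time of 48 h (on this read-out lower numbers stand for stronger inhibition and higher numbers for weaker inhibition), gives > 50000 nM, which is a limit of the assay and not a number.
Compound 2, `COc1ccc(Oc2ccc([N+](=O)[O-])cc2-c2ccsc2S(=O)(=O)N2CCN(C(=S)Nc3ccc([N+](=O)[O-])cc3)CC2)cc1OC`, in this assay gives > 50000 nM, again a limit rather than a number.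
Compound 3, `O=S(=O)(c1sccc1-c1ccccc1Oc1ccc(O)c(O)c1)N1CCN(C(=S)Nc2cc(C(F)(F)F)cc(C(F)(F)F)c2)CC1`, in this assay gives 7300 nM.

Compound 1 and compound 2 differ in one place: nitro in place of hydrogen on an aromatic carbon. The step that the two limits leave unreadable from compound 1 to compound 2 cannot be sized because of the limit of > 50000 nM in this assay, at which 2 of the 3 values shown sit. Compound 3 rests on a different core; how its core differs from that of compound 1 is not broken down here.

Compound 4, `O=[N+]([O-])c1ccc(Oc2ccc(O)c(O)c2)c(-c2ccsc2S(=O)(=O)N2CCN(C(=S)Nc3cc(C(F)(F)F)cc(C(F)(F)F)c3)CC2)c1`, has not yet been measured. It differs from compound 3 by nitro in place of hydrogen on an aromatic carbon. This is the same kind of change as from compound 1 to compound 2, but not the same: there the carbon is para to a 3,4-dimethoxyphenoxy group, here it is para to a 3,4-dihydroxyphenoxy group. Since the earlier step gives no readable size, the expectation rests on compound 3 alone with 7300 nM. The step of a 1.0-fold lower number from compound 3 to compound 4 (0.02 log units; within the scatter) is expected to stay small. Compound 4 is therefore estimated at 7000 nM, most likely between 2000 nM and 30000 nM.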

Compound 4, half-maximal inhibitory concentration: 9500 nM
For compound 4 the middle estimate is 1.4-fold (0.13 log units) below the measured one; low and high end bracket the measured number.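

In this assay, placing nitro on this aromatic carbon, para to a 3,4-dihydroxyphenoxy group, gives a 1.3-fold higher number from compound 3 to compound 4 (0.11 log units; within the scatter), so on this core the change cannot be told apart from the ordinary spread of repeated measurements. The same change on the core of compound 1 cannot be sized, because the values on both sides of it are limits of the assay and not numbers: the limit of > 50000 nM in this assay, at which 2 of the 4 values shown sit. With a single readable step, the series shows that nitro in place of hydrogen has no detectable effect on one core, but it does not show that the change behaves the same way on another core.

On these data alone, whether a different group on that same carbon, such as an amine, a carboxylic acid or a nitrile, would shift the number beyond the scatter remains open. As far as these compounds go, compound 1 and compound 3 differ in more than one place, so what the 3,4-dihydroxyphenoxy group contributes on its own also remains open.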